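The source may report more compounds than this note shows. Statements on the series, on what has been measured and on what is new or still open speak of the compounds shown alone.

Compound 1 `CSc1ccc(C2=C(c3ccc(F)c(C)c3)C(=O)N3CCCC3C2)cc1`: 800 nM
Compound 2 `COc1ccc(C2=C(c3ccc(SC)cc3)CC3CCCN3C2=O)cc1OC`: 5000 nM

In a functional assay on M14 cells (Homo sapiens) for cytotoxicity (a higher number here means a weaker inhibitor of growth, a lower number a stronger inhibitor of growth), compound 2 has the higher of the two numbers, 5000 nM, so it is the weaker inhibitor of growth, and its gap to compound 1 lies beyond the scatter. Compound 3 `COc1ccc(C2=C(c3ccc(SC)cc3)CC3CCCN3C2=O)cc1` carries hydrogen in place of methoxy on an aromatic carbon. For the measured compounds named here, no two measured compounds differ in one place, so this change has no direct precedent, and only a small shift toward a lower number, not clearly beyond the scatter, is expected. The estimated change is a 1.7-fold lower number from compound 2 to compound 3 (0.22 log units; within the scatter). Compound 3 is expected at 3000 nM, with an estimated range of 800 nM to 10000 nM.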

Compound 3, concentration for 50% growth inhibition: 4000 nM
Estimate against measurement, compound 3: 1.3-fold (0.12 log units) below, and the stated range covers the measured number.
By their numbers in this assay, from the lowest: compound 1; then compounds 3 and 2 (each within the scatter of the next).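

In this assay, hydrogen in place of methoxy on the aromatic carbon gives a 1.3-fold lower number from compound 2 to compound 3 (0.10 log units; within the scatter), so this methoxy group can be lost without a change that can be told from the scatter. By contrast, 4-methoxyphenyl in place of 4-fluoro-3-methylphenyl on a double-bonded ring carbon gives a 5.0-fold higher number from compound 1 to compound 3 (0.70 log units; beyond the scatter), and of these two steps, only this one lies beyond the scatter. Nothing given here explains either step. On these data alone, whether an amine or a carboxylic acid on that aromatic carbon would give a clearly different number remains open.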